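Hydrogen in place of methoxy: compound 2 to compound 4

A few compounds are considered here, and "the series" means these few. Any claim that something is new, unique, unknown or untested is made for them only; others in the source may bear on it.

Of the compounds shown here, three have numbers so far in an ADME assay on microsomes from liver (Homo sapiens) for metabolic stability, with a stated time of 10 min; on this read-out lower numbers stand for a less stable compound and higher numbers for a more stable compound. Compound 2 (`COc1nn2cc(-c3cc4c(OC)ccc(OC)c4o3)nc2s1`) gives 55% and stands second highest of the three. Compound 1 (`COc1ccc2oc(-c3cn4nc(OC)sc4n3)cc2c1`) lies lower (30%) and compound 3 (`COc1cc(OCc2cccc(CCc3ccccc3)c2)c2cc(-c3cn4nc(OC)sc4n3)oc2c1`) lies higher (99%), with both gaps beyond the scatter.

The next compound to be read is compound 4 (`COc1nn2cc(-c3cc4c(OC)cccc4o3)nc2s1`). Compared with compound 2, it has hydrogen in place of methoxy on an aromatic carbon, on a six-membered aromatic ring of carbon only, para to a methoxy group (hydrogen in place of methoxy on an aromatic carbon).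

Among the measured compounds shown here, no two measured compounds differ in one place only, so the series offers no measured step as a guide. In this assay a small fall is expected, not clearly beyond the scatter, and a result with no real change would not be surprising. For the measured compounds named here, this expectation is weakly founded, resting only on the spread of values, in which the lowest number so far belongs to compound 1 (30%). The estimated change is a number 10 percentage points lower from compound 2 to compound 4 (within the scatter) and carries wide uncertainty. The estimate for compound 4 is 45% (expected range 25% to 65%).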

Compound 4, percent of the compound remaining: 40%
The estimate for compound 4 lay 5 percentage points above the measured number; the measured number falls inside the stated range.
By their numbers in this assay, from the lowest: compounds 1 and 4 (each within the scatter of the next); then compound 2; then compound 3.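

In this assay the series now has its first single-place change: on the six-membered aromatic ring of carbon only, replacing the methoxy para to a methoxy group with hydrogen gives a step of a number 15 percentage points lower from compound 2 to compound 4 (beyond the scatter). This position is therefore not indifferent to the change, since the methoxy here goes with the more stable of the two compounds, although the step is modest and rests on one pair. Nothing measured in the series speaks to what lies behind the step.

At this aromatic carbon the compounds shown carry only methoxy and hydrogen, so it remains open whether fluorine, a hydroxyl, an amine or a longer alkoxy chain such as ethoxy would give a number nearer to compound 2 or compound 4, or one outside both. Going by these compounds, it also remains open whether the same change would give a step of similar size on a different background, such as the larger ether-bearing compound 3, which has no single-place partner here.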